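A few compounds are considered here, and "the series" means these few. Any claim that something is new, unique, unknown or untested is made for them only; others in the source may bear on it.

Working notes on the series. Compound 2, `CC(C)[C@H]1CC[C@@]2(CO2)[C@H]2C(=O)OCC(C(=O)O)=C[C@H]12`, in a functional assay on NAMALVA cells (Homo sapiens) for inhibition, with a stated time of 72 h (a lower number here means a stronger inhibitor, a higher number a weaker inhibitor), gives 302 nM, the lowest number of the two full values here. Compound 1, `CC(C)[C@H]1CC[C@@](O)(CCl)[C@H]2C(=O)OCC(C(=O)OCc3ccc(-c4ccccc4)o3)=C[C@H]12`, gives 1110 nM in this assay, a step beyond the scatter. Compound 3, `CC(C)[C@H]1CC[C@@](O)(CO)[C@H]2C(=O)OCC(C(=O)O)=C[C@H]12`, returns only a limit in this assay, > 32000 nM, as noted in the limit of > 32000 nM in this assay, at which 1 of the 3 values shown sits. Compound 4, `CNC(=O)C1=C[C@@H]2[C@@H](C(C)C)CC[C@@]3(CO3)[C@H]2C(=O)OC1`, is not yet measured in this assay; it differs from compound 2 by methylamino in place of hydroxy on a carbonyl carbon. Among the compounds with values here, no measured pair here shows an acid-to-amide change, so the direction of the step is open. A modest weakening, not far beyond the scatter, is the working expectation, a 2.0-fold higher number from compound 2 to compound 4 (0.30 log units; within the scatter). Compound 4 is therefore estimated at 600 nM in this assay, within 150 nM to 2500 nM.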

Compound 4, half-maximal inhibitory concentration: 1280 nM
Compound 4: the middle estimate sits 2.1-fold (0.33 log units) below what was measured; the measured number falls inside the stated range.
By their numbers in this assay, from the lowest: compound 2; then compounds 1 and 4 (each within the scatter of the next). At a limit, above all of these: compound 3.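

Methylamino in place of hydroxy on this carbonyl carbon gives the first readable acid-to-amide step in this assay, a 4.2-fold higher number from compound 2 to compound 4 (0.63 log units; beyond the scatter), so the change carries a cost beyond the scatter. Compound 4 still gives a full value without the carboxy group, so a free acid at this position is not required for a measurable number. No measurement shown accounts for the size of this step.

As far as these compounds go, whether an unsubstituted amide, a dimethylamino amide or a longer chain on the amide nitrogen would give a similar step remains open. Also open, from the compounds shown here alone, is whether the same change would hold on a different core.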